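A fluorine on the phenyl of compound 2

The source may report more compounds than this note shows. Statements on the series, on what has been measured and on what is new or still open speak of the compounds shown alone.

Compound 1, `C=C1C[C@]23C[C@@]1(O)CC[C@H]2c1cc(Br)c(O)c(C)c1[C@@H]3Cn1cc(-c2ccc(C)cc2)nn1`: > 20000 nM
Compound 2, `C=C1C[C@]23C[C@@]1(O)CC[C@H]2c1cc(Br)c(O)c(C)c1[C@@H]3Cn1cc(-c2ccccc2)nn1`: > 20000 nM
Compound 3, `C=C1C[C@]23C[C@@]1(O)CC[C@@H]2c1cccc(C)c1[C@@H]3Cn1cc(-c2ccc(OC)cc2)nn1`: > 20000 nM

In a functional assay on HL-60 cells (Homo sapiens) for cytotoxicity, read by MTT assay, with a stated time of 4 days (a higher number here means a weaker inhibitor, a lower number a stronger inhibitor), every value shown so far is a limit of the assay rather than a number. Compound 1 gives > 20000 nM, a limit. Compound 2 gives > 20000 nM, also a limit. Compound 3 gives > 20000 nM, again a limit. For the measured compounds named here, the one step between neighbours, a step that the two limits leave unreadable from compound 1 to compound 2, cannot be read because the limit of > 20000 nM in this assay, at which 3 of the 3 values shown sit, holds both of its ends. Compound 2 therefore stands at the limit, with nothing in the numbers to set it apart from the other two.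

Compound 4, `C=C1C[C@]23C[C@@]1(O)CC[C@H]2c1cc(Br)c(O)c(C)c1[C@@H]3Cn1cc(-c2ccc(F)cc2)nn1`, is not yet measured. It differs from compound 2 by fluoro in place of hydrogen on an aromatic carbon; seen one bond further out, a phenyl becomes a 4-fluorophenyl. No measured step bears on this change, and the only step shown is unreadable, so neither a size nor a direction can be taken from the data. The nearest guide is that compound 1 and compound 3 also sit at the limit.

Compound 4 is expected to remain at the limit, with an estimated 40000 nM and a range from 15000 nM to 100000 nM. The expected step is then a step that the limit leaves unreadable from compound 2 to compound 4, nothing beyond the scatter.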

Compound 4, half-maximal inhibitory concentration: 6600 nM
Compound 4: the middle estimate sits 6.1-fold (0.78 log units) above what was measured; measured number below the stated range.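

For the compounds shown here, until now this position on the phenyl gave no information: every compound stood at the same limit, and the one step among them could not be read. In this assay, putting fluoro in place of hydrogen on the aromatic carbon para to a large group, a change of a single heavy atom, gives an at least 3.0-fold lower number from compound 2 to compound 4 (0.48 log units; beyond the scatter), and putting fluoro in place of methyl on that same carbon gives an at least 3.0-fold lower number from compound 1 to compound 4 (0.48 log units; beyond the scatter), so this carbon does affect the read-out and the choice of group there matters. Both sizes are only minimum sizes, because each step starts from a compound with no exact number: the limit of > 20000 nM in this assay, at which 3 of the 4 values shown sit.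

The compounds shown leave open whether fluoro is special at this carbon or whether another group there, such as chloro, an amine or a carboxylic acid, would lower the number as well or further. Also open, going by these compounds, is whether the effect of fluoro would carry over to the core of compound 3, which has neither the bromo nor the hydroxy group of the core of compound 2.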